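Methoxymethyl on the nitrogen of compound 3

The compounds below may be only part of what the source reports. "The series", "measured", "known", "first", "only" and "open" are said of these compounds alone.

Measured in a functional assay on cells (Endothelial cell, Homo sapiens) for inhibition, read by radioligand binding; a higher number here means a weaker inhibitor, a lower number a stronger inhibitor:
Compound 1 `COc1ccc2c(c1)C(OC(C)C)=C(C(N)=O)S2(=O)=O`: < 4000 nM (a limit, not a number)
Compound 2 `COc1ccc2oc(C(N)=O)c(OC(C)C)c2c1`: 14000 nM
Compound 3 `COc1ccc2[nH]c(C(N)=O)c(OC(C)C)c2c1`: 8000 nM

Compound 1 is known only by its limit of < 4000 nM. Among the two true numbers, compound 3 holds the lower one at 8000 nM, but that lies within the scatter of compound 2 at 14000 nM.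

Compound 4 `COCn1c(C(N)=O)c(OC(C)C)c2cc(OC)ccc21` has methoxymethyl in place of hydrogen on an aromatic nitrogen of compound 3 (methoxymethyl in place of hydrogen on an aromatic nitrogen). Going by the values given here, no measured step shows what such a change does in this assay, so no shift beyond the scatter is expected. The expected step is a 1.3-fold higher number from compound 3 to compound 4 (0.10 log units; within the scatter). Compound 4 is estimated at 10000 nM, with an expected range of 4000 nM to 25000 nM.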

Compound 4, half-maximal inhibitory concentration: 34000 nM
The estimate for compound 4 lay 3.4-fold (0.53 log units) below the measured number, and the stated range ends below it.
By their numbers in this assay, from the lowest: compounds 3 and 2 (each within the scatter of the next); then compound 4. At a limit, below all of these: compound 1.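

In this assay, methoxymethyl in place of hydrogen on the aromatic nitrogen gives a 4.3-fold higher number from compound 3 to compound 4 (0.63 log units; beyond the scatter). Going by these compounds alone, this is the first change read at this position, and it shows that the position is not indifferent: the substituted compound is the weaker inhibitor. Nothing measured here accounts for the loss.

As far as these compounds go, whether methyl or an aminoethyl chain on this nitrogen would cost as much remains open. Compound 1 is held only by a limit, not a number, so its place among the others stays unsettled: the limit of < 4000 nM in this assay, at which 1 of the 4 values shown sits.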